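A few compounds are considered here, and "the series" means these few. Any claim that something is new, unique, unknown or untested is made for them only; others in the source may bear on it.

Compound 3 `O=C(NC(=S)Nc1nc2ccccc2s1)c1ccccc1` gives 37300 nM in a functional assay on MCF7 cells (Homo sapiens) for cytotoxicity, read by MTT assay, with a stated time of 24 h; on this read-out lower numbers stand for stronger inhibition and higher numbers for weaker inhibition. Its two companions are close: compound 1 `O=C(NC(=S)Nc1nc2ccccc2s1)c1ccc([N+](=O)[O-])cc1` gives 33800 nM and compound 2 `O=C(NC(=S)Nc1nc2cc(Br)ccc2s1)c1ccccc1` gives 32100 nM, and the differences, a 1.1-fold higher number from compound 1 to compound 3 (0.04 log units; within the scatter) and a 1.2-fold higher number from compound 2 to compound 3 (0.07 log units; within the scatter), do not separate any of the three. Compound 4 `O=C(NC(=S)Nc1nc2ccccc2s1)N1CCOCC1` is built from compound 3 by one change, (morpholin-4-yl in place of phenyl on a carbonyl carbon), a swap of the group attached to the carbonyl carbon rather than on the aromatic part. Neither measured step touches this position; both concern substituents on an aromatic carbon and both stayed within the scatter, so they offer no direct guide to what an exchange at the carbonyl carbon does. In the absence of a comparable step, the expectation for compound 4 in this assay is simply a number near that of compound 3, with a wide range to reflect the missing precedent, so a 1.1-fold higher number from compound 3 to compound 4 (0.03 log units; within the scatter) is expected to be small. Compound 4 is therefore estimated at 40000 nM, within 14000 nM to 120000 nM.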

Compound 4, half-maximal inhibitory concentration: 29300 nM
Compound 4: the middle estimate sits 1.4-fold (0.14 log units) above what was measured, and the stated range covers the measured number.
By their numbers in this assay, from the lowest: compounds 4, 2, 1 and 3 (each within the scatter of the next).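

The earlier steps shown here concerned only substituents on an aromatic carbon, whereas this one exchanges the group on the carbonyl carbon, and in this assay it gives a 1.3-fold lower number from compound 3 to compound 4 (0.10 log units; within the scatter). For this pair, then, a six-membered aromatic ring of carbon only can be replaced at this place by a non-aromatic ring holding two hetero atoms and a hydrogen-bond acceptor, with no change that can be told from the scatter. No measurement on hand explains this result.

The compounds shown leave open whether other groups on the carbonyl carbon, such as piperazin-1-yl, a dimethylamino group or a longer alkyl chain, would behave in the same way. They also leave open whether any change to this series can move the number beyond the scatter.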